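Swapping Bromo for Trifluoromethyl on a Shared Core

The compounds below may be only part of what the source reports. "The series", "measured", "known", "first", "only" and "open" are said of these compounds alone.

Among the measured compounds shown here, the three compounds measured so far share one core and differ only in a single aromatic substituent. Compound 1 `CN1CCCN(CCn2ccc3ccc(Br)cc32)CC1` carries a bromo group, and in an assay on HEK293 cells for binding affinity to 5-hydroxytryptamine receptor 7 (Homo sapiens), read by radioligand binding (a lower number here means a stronger inhibitor, a higher number a weaker inhibitor), compound 1 gives 31 nM, the lowest of the three numbers. Compound 2 `CN1CCCN(CCn2ccc3cc(Br)ccc32)CC1` carries its bromo group on a different aromatic carbon, and in this assay compound 2 gives 88 nM, the nearest of the other values to compound 1. Compound 3 `CN1CCCN(CCn2ccc3ccc(F)cc32)CC1` keeps the placement of compound 1 but carries fluoro, and in this assay compound 3 gives 288 nM.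

Compound 4 `CN1CCCN(CCn2ccc3ccc(C(F)(F)F)cc32)CC1` is reached from compound 1 by one change: trifluoromethyl in place of bromo on an aromatic carbon. For the measured compounds named here, the only measured step at the same place is a 9.3-fold higher number from compound 1 to compound 3 (0.97 log units; beyond the scatter), which shows that this carbon does not tolerate every substituent equally. Going by the values given here, no measured step tells how a trifluoromethyl group would fare there; the step to fluoro is the closest guide, and it weakened binding, so a smaller weakening is the expectation for the larger group. Compound 4 is therefore expected to show a 2.3-fold higher number from compound 1 to compound 4 (0.35 log units; beyond the scatter) in this assay. The estimate for compound 4 is 70 nM, with a range from 20 nM to 250 nM.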

Compound 4, inhibition constant: 23 nM
For compound 4 the middle estimate is 3.0-fold (0.48 log units) above the measured one, within the range that was stated.
By their numbers in this assay, from the lowest: compounds 4 and 1 (each within the scatter of the next); then compound 2; then compound 3.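

In this assay, trifluoromethyl in place of bromo gives a 1.3-fold lower number from compound 1 to compound 4 (0.13 log units; within the scatter), so at this aromatic carbon, meta to a fused ring and para to a fused ring, the two groups cannot be told apart, although trifluoromethyl brings 4 heavy atoms where bromo had 1. Trifluoromethyl in place of fluoro gives a 13-fold lower number from compound 3 to compound 4 (1.10 log units; beyond the scatter), and together with a 9.3-fold higher number from compound 1 to compound 3 (0.97 log units; beyond the scatter) this sets compound 3 apart from compound 1 and compound 4, showing that the weaker binding seen with fluoro does not extend to a fluorine-bearing group as such. Nothing at hand explains why fluoro stands apart from bromo and trifluoromethyl at this carbon.

On these data alone, whether a methoxy group, a nitrile or an amine on this same carbon would stay close to bromo and trifluoromethyl or move towards fluoro remains open. As far as these compounds go, it is also open whether trifluoromethyl on the aromatic carbon that carries bromo in compound 2 would match that bromo compound in the way compound 4 matches compound 1.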